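Swapping a benzyl ether for a prenyl ether in MCF7 cells

The compounds below may be only part of what the source reports. "The series", "measured", "known", "first", "only" and "open" are said of these compounds alone.

Measured so far:
compound 1, `CC(C)=CCOc1c(C)c(C)c2c(c1C)CCC(C)(COc1ccc(/C=C3\SC(=O)NC3=O)cc1Br)O2`: 53%
compound 2, `CC(C)=CCOc1c(C)c(C)c2c(c1C)CCC(C)(COc1ccc(/C=C3\SC(=O)NC3=O)cc1-c1ccc(F)cc1)O2`: 85%
compound 3, `Cc1c(C)c2c(c(C)c1OCc1ccccc1)CCC(C)(COc1ccc(/C=C3\SC(=O)NC3=O)cc1)O2`: 12%

In a functional assay on MCF7 cells (Homo sapiens), tested at 7.5 uM (a higher number here means a weaker effect of the compound at the concentration tested, a lower number a stronger effect), compound 3 gives 12%, the lowest of the three numbers; compound 1 lies next with 53%, and compound 2 furthest with 85%, both gaps beyond the scatter. Compound 4, `CC(C)=CCOc1c(C)c(C)c2c(c1C)CCC(C)(COc1ccc(/C=C3\SC(=O)NC3=O)cc1)O2`, keeps the core of compound 3 but carries the change (2-methylprop-1-en-1-yl in place of phenyl on a saturated chain carbon bound to an oxygen on an aromatic ring).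

Among the compounds with values here, the only measured step, a number 32 percentage points higher from compound 1 to compound 2 (beyond the scatter), concerns a different place in the structure and so bears on this change only loosely. Compound 1 and compound 3 differ in two places at once, so their gap cannot be assigned to the ether alone. Within the data shown here, with no direct precedent, the account expects a modest rise in this assay for compound 4, a number 18 percentage points higher from compound 3 to compound 4 (beyond the scatter), with wide uncertainty; the estimate for compound 4 is 30%, from 8% to 60%.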

Compound 4, a percentage reported as activity, at one concentration (the size of the read-out at that concentration, not a potency): 5%
Estimate against measurement, compound 4: 25 percentage points above; measured number below the stated range.
By their numbers in this assay, from the lowest: compounds 4 and 3 (each within the scatter of the next); then compound 1; then compound 2.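

In this assay the ether position tolerates the change: benzyl gives way to 3-methylbut-2-en-1-yl with a number 7 percentage points lower from compound 3 to compound 4 (within the scatter) and no separable effect on the read-out. Compound 4 also gives the first single-change view of the aromatic carbon that carries bromo in compound 1, since hydrogen in place of bromo gives a number 48 percentage points lower from compound 1 to compound 4 (beyond the scatter) and is a large step. Hydrogen in place of 4-fluorophenyl gives a number 80 percentage points lower from compound 2 to compound 4 (beyond the scatter) and is also large, so with this ether the substituent on that carbon matters far more than the swap at the ether.

No evidence at hand bears on the reasons for these steps. The compounds shown leave open whether a longer chain, or one ending in an amine or a carboxylic acid, would be tolerated at the ether position.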